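The source may hold more compounds than are shown below. What is called first, only, known or untested is meant among the compounds shown, and "the series" means these compounds.

Of the compounds shown here, two sharing one core have so far been tested in a functional assay on A549 cells (Homo sapiens) for antiproliferative activity, read by MTT assay, with a stated time of 72 h; on this read-out lower numbers stand for stronger inhibition and higher numbers for weaker inhibition. Compound 1 `CC/C=C/C(=O)Nc1cccc(Oc2nc(Nc3ccn(C)n3)nc3c2CSCC3)c1` gives 36800 nM. Going by the values given here, compound 2 `CC(C)/C=C/C(=O)Nc1cccc(Oc2nc(Nc3ccn(C)n3)nc3c2CSCC3)c1` gives 33500 nM, which lies within the usual scatter of its only neighbour, so the two stand level on these numbers. Among the compounds with values here, the only measured step, a 1.1-fold lower number from compound 1 to compound 2 (0.04 log units; within the scatter), is a methyl in place of hydrogen on the saturated chain.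

Compound 3 `CC(C)/C=C/C(=O)Nc1cccc(Oc2nc(Nc3cccc(C#N)c3)nc3c2CSCC3)c1` keeps the chain of compound 2 and changes a different place: 3-cyanophenyl in place of 1-methyl-1H-pyrazol-3-yl on a nitrogen on an aromatic ring. In plain terms, 3-cyanophenyl sits in place of 1-methyl-1H-pyrazol-3-yl on a nitrogen on an aromatic ring. Within the data shown here, the one measured step lies elsewhere in the molecule, so it offers little guidance here, and no measured pair shows what a change on this nitrogen does. With no direction supported by the data, no step beyond the scatter is expected, although the uncertainty is wide. The expected step is a 1.3-fold lower number from compound 2 to compound 3 (0.13 log units; within the scatter). The estimate for compound 3 is 25000 nM, with an expected range of 7000 nM to 70000 nM.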

Compound 3, half-maximal inhibitory concentration: 35900 nM
The estimate for compound 3 lay 1.4-fold (0.16 log units) below the measured number; measured number inside the range.
By their numbers in this assay, from the lowest: compounds 2, 3 and 1 (each within the scatter of the next).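

In this assay, going by these compounds alone, the first measured change on this nitrogen is a 1.1-fold higher number from compound 2 to compound 3 (0.03 log units; within the scatter) and so adds a second place on the molecule where a swap leaves the two numbers level. The two groups differ in what is counted: 1-methyl-1H-pyrazol-3-yl has 6 heavy atoms, a five-membered aromatic ring with 2 hetero atoms and 2 hydrogen-bond acceptors, while 3-cyanophenyl has 8 heavy atoms, a six-membered aromatic ring of carbon only, a triple bond and 1 hydrogen-bond acceptor, yet this pair shows no separation on this read-out. Nothing measured on these compounds speaks to why the two groups stand level.

Both groups on this nitrogen are aromatic rings, so the compounds shown leave open how a group without an aromatic ring, such as a piperidine or a plain ethyl chain, would read in this position. They also leave open whether a 3-cyanophenyl ring carrying a carboxylic acid, or a longer chain at the other end of the molecule, would move the number beyond the scatter.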